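N-Methylation on the benzylamino chain

A few compounds are considered here, and "the series" means these few. Any claim that something is new, unique, unknown or untested is made for them only; others in the source may bear on it.

Compound 1 (`CC(C)=CCc1cc(C(=O)Nc2cc3ccc(OCC4CCCNC4)c(C)c3oc2=O)ccc1O`), compound 2 (`CCN(C)CCCOc1ccc2cc(NC(=O)c3ccc(O)c(CC=C(C)C)c3)c(=O)oc2c1C`) and compound 3 (`CC(C)=CCc1cc(C(=O)Nc2cc3ccc(OCCCNCc4ccccc4)c(C)c3oc2=O)ccc1O`) share one core and differ only in the amine group on the chain carried by an oxygen on an aromatic ring. In a functional assay on SK-BR-3 cells (Homo sapiens) for antiproliferative activity (a lower number here means a stronger inhibitor, a higher number a weaker inhibitor), compound 1 gives 600 nM, compound 2 gives 730 nM and compound 3 gives 470 nM. Compound 3 therefore stands within the scatter of both others, and the numbers do not separate the three.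

Compound 4 (`CC(C)=CCc1cc(C(=O)Nc2cc3ccc(OCCCN(C)Cc4ccccc4)c(C)c3oc2=O)ccc1O`) takes methyl in place of hydrogen on an amine nitrogen, turning benzylamino into benzyl(methyl)amino: methyl in place of hydrogen on an amine nitrogen.

Going by the values given here, no measured step makes this exact change. The closest is a 1.6-fold lower number from compound 2 to compound 3 (0.19 log units; within the scatter), at the same place on the chain. The other two are a 1.3-fold lower number from compound 1 to compound 3 (0.11 log units; within the scatter) and a 1.2-fold higher number from compound 1 to compound 2 (0.09 log units; within the scatter). All three lie within the scatter, so no step beyond it is expected in this assay. Compound 2 also carries a methyl on its amine nitrogen, and its 730 nM is the nearest guide to a compound of that kind.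

The expected change is small, an estimated 1.1-fold higher number from compound 3 to compound 4 (0.05 log units; within the scatter).

For compound 4 the estimated value is 530 nM, with an expected range of 260 nM to 1000 nM.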

Compound 4, half-maximal inhibitory concentration: 10700 nM
For compound 4 the middle estimate is 20-fold (1.31 log units) below the measured one; measured number above the stated range.
By their numbers in this assay, from the lowest: compounds 3, 1 and 2 (each within the scatter of the next); then compound 4.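

In this assay, going by these compounds alone, the methyl on the amine nitrogen gives a 23-fold higher number from compound 3 to compound 4 (1.36 log units; beyond the scatter) and so shows what the amine changes among compound 1, compound 2 and compound 3 did not: this place on the chain can respond strongly, all the earlier steps having stayed within the scatter. A methyl on that nitrogen does not bring the loss by itself, since compound 2 also carries one, and phenyl in place of methyl on the saturated chain carbon bound to the amine nitrogen gives a 15-fold higher number from compound 2 to compound 4 (1.17 log units; beyond the scatter) while the change from the piperidin-3-yl group gives an 18-fold higher number from compound 1 to compound 4 (1.25 log units; beyond the scatter) in the same direction. Among these four compounds the loss appears only where benzyl and methyl share one nitrogen, and no measurement at hand offers a reason for it.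

Open, as far as these compounds go, is whether an ethyl or an acetyl on this nitrogen would stand with compound 3 or with compound 4. Also open, from the compounds shown here alone, is whether the benzyl(methyl)amino group would behave the same way on a shorter or longer chain, or whether a piperidine carrying benzyl on its nitrogen would follow it.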